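Pyrazinyl carbonyl variant of an indolyl triazole series

The compounds below may be only part of what the source reports. "The series", "measured", "known", "first", "only" and "open" are said of these compounds alone.

Measured so far:
compound 1 `COc1ccc(Cn2c(CCc3ccccc3)nnc2[C@H](NC(=O)c2ccncc2)c2c[nH]c3ccccc23)cc1`, an in vitro assay on LLC-PK1 cells for displacement of a labelled ligand from growth hormone secretagogue receptor type 1 (Homo sapiens); on this read-out higher numbers stand for weaker inhibition and lower numbers for stronger inhibition: 220 nM
compound 2 `COc1ccc(Cn2c(CCc3ccccc3)nnc2[C@H](NC(=O)Cc2ccncc2)c2c[nH]c3ccccc23)cc1`, this assay: 270 nM

Compound 2 stands highest of the two numbers, yet its nearest neighbour, compound 1, lies within the scatter: a 1.2-fold higher number from compound 1 to compound 2 (0.09 log units; within the scatter). Compound 3 `COc1ccc(Cn2c(CCc3ccccc3)nnc2[C@H](NC(=O)c2cnccn2)c2c[nH]c3ccccc23)cc1` differs from compound 2 by pyrazin-2-yl in place of (pyridin-4-yl)methyl on a carbonyl carbon. Within the data shown here, the only step on hand, from compound 1 to compound 2, was within the scatter, so no move beyond the scatter is expected here. Compound 3 is estimated at 250 nM, ranging from 100 nM to 650 nM, which means an expected step of a 1.1-fold lower number from compound 2 to compound 3 (0.03 log units; within the scatter).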

Compound 3, half-maximal inhibitory concentration: 14 nM
The estimate for compound 3 lay 18-fold (1.25 log units) above the measured number; the whole stated range lies above it.
By their numbers in this assay, from the lowest: compound 3; then compounds 1 and 2 (each within the scatter of the next).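

At the carbonyl carbon of the amide, the earlier change from pyridin-4-yl to (pyridin-4-yl)methyl stayed within the scatter, but in this assay pyrazin-2-yl gives a 19-fold lower number from compound 2 to compound 3 (1.29 log units; beyond the scatter) and a 16-fold lower number from compound 1 to compound 3 (1.20 log units; beyond the scatter) as well. This position therefore responds strongly to the group it carries, which the first two compounds could not show. Nothing on hand bears on what lies behind this drop. Going by these compounds, whether pyridin-2-yl, phenyl or pyrimidin-2-yl on this carbonyl carbon would match pyrazin-2-yl stays open, as does the effect of (pyrazin-2-yl)methyl there.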